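Chloro in place of cyano: working notes

This account rests on a few compounds, and the source may have more. Where it says the series, first, only, none or still open, it means among the compounds named here.

Measured in a functional assay on MDA-MB-231 cells (Homo sapiens) for inhibition, read by MTT assay, with a stated time of 48 h; on this read-out higher numbers stand for weaker inhibition and lower numbers for stronger inhibition:
- compound 1 (`Cc1ccc(-c2nc3ccccn3c2Sc2ccccc2)cc1`): > 100000 nM, a limit
- compound 2 (`N#Cc1ccc(-c2nc3ccccn3c2Sc2ccccc2)cc1`): 17800 nM

Compound 1 has a limit of the assay and not a number. Among the measured compounds shown here, compound 2 holds the only true number so far, so it has no measured neighbour to rank against. Compound 3 (`Clc1ccc(-c2nc3ccccn3c2Sc2ccccc2)cc1`) carries chloro in place of cyano on an aromatic carbon, para to a large group (chloro in place of cyano on an aromatic carbon). For the measured compounds named here, the one step bearing on this place is an at least 5.6-fold lower number from compound 1 to compound 2 (0.74 log units; beyond the scatter), with cyano in place of methyl, and it rests on (the limit of > 100000 nM in this assay, at which 1 of the 2 values shown sits). A modest move back to a higher number in this assay is therefore expected, as a 2.2-fold higher number from compound 2 to compound 3 (0.35 log units; beyond the scatter) in estimate. For compound 3 the estimated value is 40000 nM, with an expected range of 15000 nM to 100000 nM in this assay.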

Compound 3, half-maximal inhibitory concentration: 24500 nM
Compound 3: the middle estimate sits 1.6-fold (0.21 log units) above what was measured, and the stated range covers the measured number.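

In this assay, cyano and chloro at this place, on an aromatic carbon para to a large group, cannot be told apart: a 1.4-fold higher number from compound 2 to compound 3 (0.14 log units; within the scatter). The result therefore gives this position a second true number, and two quite different groups leave it at the same level. Methyl is separated from both, with an at least 4.0-fold lower number from compound 1 to compound 3 (0.61 log units; beyond the scatter), but the size of that step stays open, as it rests on a limit: the limit of > 100000 nM in this assay, at which 1 of the 3 values shown sits.

On these data alone, how an amine or a carboxylic acid would read at this place remains open. The compounds shown also leave open whether the same level holds when the rest of the shared core changes.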